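This account rests on a few compounds, and the source may have more. Where it says the series, first, only, none or still open, it means among the compounds named here.

Working notes on the series in a functional assay on COLO 205 cells (Homo sapiens) for inhibition, read by MTT assay, with a stated time of 48 h; a higher number here means a weaker inhibitor, a lower number a stronger inhibitor:
- compound 1 `COc1cccc(/C=C/C(=O)c2cc(OC)c(OC)c(OC)c2)c1OC`: 13200 nM
- compound 2 `COc1cc(C(=O)/C=C/c2ccc(O)cc2)cc(OC)c1OC`: 29700 nM
- compound 3 `COc1cc(/C=C/C(=O)c2cc(OC)c(OC)c(OC)c2)ccc1O`: > 100000 nM

For compound 3, > 100000 nM is a limit of the assay and not a number. Of the two actual numbers, compound 2 has the higher, and compound 1 stands lower at 13200 nM.

Compound 4 `COc1cc(C(=O)/C=C/c2ccc(Br)cc2)cc(OC)c1OC` differs from compound 2 by bromo in place of hydroxy on an aromatic carbon, para to a large group.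

Among the compounds with values here, the one measured step, methoxy in place of hydrogen, is an at least 3.3-fold higher number from compound 2 to compound 3 (0.52 log units; beyond the scatter). It is a different change and bears only loosely, showing that this ring can move the number. Within the data shown here, compound 1, the only measured compound without hydroxy, gives 13200 nM, which suggests a modest fall. The expected change is a 2.0-fold lower number from compound 2 to compound 4 (0.30 log units; within the scatter), towards a lower number. The estimate for compound 4 is 15000 nM, with an expected range of 5000 nM to 45000 nM.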

Compound 4, half-maximal inhibitory concentration: 22500 nM
Beside the measured number, compound 4's estimate is 1.5-fold (0.18 log units) below it; the range from low to high includes it.
By their numbers in this assay, from the lowest: compounds 1, 4 and 2 (each within the scatter of the next, the first and the last beyond it). At a limit, above all of these: compound 3.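

In this assay, bromo in place of hydroxy, para to a large group, gives a 1.3-fold lower number from compound 2 to compound 4 (0.12 log units; within the scatter). Within the data shown here, this position therefore tolerates losing the hydroxy and its hydrogen-bond donor without a shift beyond the scatter, which the earlier compounds could not show, as none of them differs from compound 2 by this change alone. Nothing shown accounts for this step. On these data alone, whether an amine or a carboxylic acid at this position would hold the number in the same range remains open.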